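Series notes: compound 1 and its 5-methylpyridin-2-yl analogue

A few compounds are considered here, and "the series" means these few. Any claim that something is new, unique, unknown or untested is made for them only; others in the source may bear on it.

Measured so far:
compound 1, `C[C@H](/N=C(\S)Nc1ccccn1)c1cccc2ccccc12`: > 100000 nM (a limit)
compound 2, `CCOC(=O)Cc1csc(/N=C(\S)N[C@H](C)c2cccc3ccccc23)n1`: 2 nM
compound 3, `Cc1cccc2sc(N/C(S)=N/[C@@H](C)c3cccc4ccccc34)nc12`: > 100000 nM (a limit)

In a functional assay on RBL-2H3 cells (Rattus norvegicus) for inhibition (on this read-out lower numbers stand for stronger inhibition and higher numbers for weaker inhibition), compound 1 gives no number, only the limit > 100000 nM. Compound 3 likewise stands at a limit, > 100000 nM. Only compound 2 gives a measurable value, 2 nM. Two of the three values shown sit at the limit of > 100000 nM in this assay, at which 2 of the 3 values shown sit, so compound 1 stands at the weak end of what has been measured.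

Compound 4, `Cc1ccc(N/C(S)=N/[C@@H](C)c2cccc3ccccc23)nc1`, differs from compound 1 by one change: methyl in place of hydrogen on an aromatic carbon. Among the compounds with values here, no measured pair shows the effect of this change, so the expectation rests on compound 1 alone. The step of a number no higher from compound 1 to compound 4 (the limit leaves the size open) is expected to stay within the scatter, most likely with compound 4 again reported as a limit. Compound 4 is estimated at 100000 nM, expected between 20000 nM and 300000 nM.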

Compound 4, half-maximal inhibitory concentration: > 100000 nM
Compound 4: a limit, no number (the forecaster's own chance of this, stated with the estimate: 75%); the middle value lies on the limit itself.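

Compound 1 and compound 4 are both reported only as limits, so no step can be read between them: the limit of > 100000 nM in this assay, at which 3 of the 4 values shown sit.

The compounds shown leave open whether pyridin-2-yl and 5-methylpyridin-2-yl differ at all in inhibition.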